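The source may report more compounds than this note shows. Statements on the series, on what has been measured and on what is new or still open speak of the compounds shown alone.

Measured in a functional assay on U-937 cells (Homo sapiens) for inhibition, read by MTT assay, with a stated time of 24 h; a lower number here means a stronger inhibitor of growth, a higher number a weaker inhibitor of growth:
- compound 1 `O=C1CC(c2ccc(NC(=O)Nc3cccc(Cl)c3)cc2)=Nc2cnn(Cc3ccccc3)c2N1` gives 670 nM
- compound 2 `COc1ccc(Cn2ncc3c2NC(=O)CC(c2cccc(NC(=O)Nc4ccc(Cl)cc4)c2)=N3)cc1` gives 580 nM
- compound 3 `O=C1CC(c2cccc(NC(=O)Nc3ccc(Cl)cc3)c2)=Nc2cn[nH]c2N1` gives > 30000 nM (a limit of the assay)

Within the data shown here, compound 2 stands within the scatter of compound 1, and these are the only two numbers available. Among the measured compounds shown here, the one measured step, an at least 51-fold higher number from compound 2 to compound 3 (1.71 log units; beyond the scatter), is large, but it is hydrogen in place of 4-methoxybenzyl on an aromatic nitrogen, a different place from the change considered here.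

Compound 4 `COc1ccc(Cn2ncc3c2NC(=O)CC(c2cccc(NC(=O)Nc4ccc(C(F)(F)F)cc4)c2)=N3)cc1` keeps the 4-methoxybenzyl group. Its difference from compound 2 is trifluoromethyl in place of chloro on an aromatic carbon, para to a large group. For the measured compounds named here, no measured step covers this change, so in this assay the expectation for compound 4 rests on compound 2, which gives 580 nM. The expected step is a 1.1-fold lower number from compound 2 to compound 4 (0.02 log units; within the scatter). For compound 4 the estimated value is 550 nM, with an expected range from 220 nM to 1400 nM.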

Compound 4, concentration for 50% growth inhibition: 110 nM
Compound 4: middle estimate off by 5.0-fold (0.70 log units), on the high side, and the stated range ends above it.
By their numbers in this assay, from the lowest: compound 4; then compounds 2 and 1 (each within the scatter of the next). At a limit, above all of these: compound 3.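

In this assay, trifluoromethyl in place of chloro gives a 5.3-fold lower number from compound 2 to compound 4 (0.72 log units; beyond the scatter), the first measured sign that the group on this aromatic carbon, para to a large group, matters as well as the group on the aromatic nitrogen. The 4-methoxybenzyl group stays the same across this change, so the step belongs to the move from 4-chlorophenyl to 4-(trifluoromethyl)phenyl alone. Nothing measured here accounts for the size of this step. Still open, as far as these compounds go, is whether a nitrile or an amine on this carbon would give a number as low as that of compound 4.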